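Selenocyanate carbamates: cytotoxicity toward a bronchial cell line

The source may report more compounds than this note shows. Statements on the series, on what has been measured and on what is new or still open speak of the compounds shown alone.

Measured compounds:
compound 1, `COc1ccc(OC(=O)Nc2ccc([Se]C#N)cc2)cc1`, 48400 nM
compound 2, `CC(C)COC(=O)Nc1ccc([Se]C#N)cc1`, 49500 nM

In an ADME assay on BEAS-2B cells (Homo sapiens) for cytotoxicity, read by MTT assay, with a stated time of 72 h (on this read-out lower numbers stand for stronger inhibition of growth and higher numbers for weaker inhibition of growth), compound 1 gives 48400 nM and compound 2 gives 49500 nM; the two numbers lie within the scatter of each other, so neither can be set apart from the other. For the measured compounds named here, no step between measured compounds is available. Compound 3, `N#C[Se]c1ccc(NC(=O)Oc2ccc(F)cc2)cc1`, carries fluoro in place of methoxy on an aromatic carbon. With two numbers that do not separate, a step from compound 1 to compound 3 of no more than the scatter, in either direction, is expected: a 1.0-fold higher number from compound 1 to compound 3 (0.01 log units; within the scatter). For compound 3 the expected value in this assay is 50000 nM, within a range from 25000 nM to 100000 nM.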

Compound 3, concentration for total growth inhibition: 45600 nM
For compound 3 the middle estimate is 1.1-fold (0.04 log units) above the measured one; measured number inside the range.
By their numbers in this assay, from the lowest: compounds 3, 1 and 2 (each within the scatter of the next).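

In this assay, fluoro in place of methoxy on an aromatic carbon, para to a large group, gives a 1.1-fold lower number from compound 1 to compound 3 (0.03 log units; within the scatter) and so leaves the read-out unresolved from that of the methoxy compound. This first single-place comparison in the series shows that this change at this position produces no readable step. No supporting data bear on this result. As far as these compounds go, whether an amine or a carboxylic acid on the same aromatic carbon would also stay within the scatter remains open.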